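Azide for thiol on the fused core: expected inhibition

The source may report more compounds than this note shows. Statements on the series, on what has been measured and on what is new or still open speak of the compounds shown alone.

Two nucleoside analogues on a shared fused core have been measured so far in a functional assay on EL4 cells (Mus musculus) for inhibition, tested at 100 uM; a lower number here means less inhibition, a higher number more inhibition at the concentration tested (going by the name of the read-out). Compound 1 `Nc1nccc2c1ncn2[C@H]1C[C@H](O)[C@@H](CO)O1` carries an amino group on the core and gives 89% in this assay. Compound 2 `OC[C@H]1OC(n2cnc3c(S)nccc32)[C@H](O)[C@@H]1O` carries a sulfanyl group at the corresponding place and reaches only the limit of this assay, < 5%, which is a limit of detection and not a measured number; compound 2 therefore stands at the floor of the numbers shown, as stated in the limit of < 5% in this assay, at which 1 of the 2 values shown sits. Whether the two compounds differ by more than the amino-to-sulfanyl exchange is not assessed here, since they also differ in the sugar.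

The next compound, compound 3 `[N-]=[N+]=Nc1nccc2c1ncn2C1O[C@H](CO)[C@@H](O)[C@H]1O`, keeps the sugar of compound 2 and changes only the group on the core: azido in place of sulfanyl on an aromatic carbon. Among the compounds with values here, no measured step of this kind exists, so the expectation rests on the two values alone. A modest rise in this assay is expected, with a number at least 10 percentage points higher from compound 2 to compound 3 (that floor lies within the scatter) as the estimated step from the limit held by compound 2. For compound 3 the expected inhibition is 15%, with a range from 0% to 45%.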

Compound 3, a percentage reported as inhibition, at one concentration (the size of the read-out at that concentration, not a potency): < 5%
Compound 3 gave a limit, no number (the forecaster's own chance of this, stated with the estimate: 40%); at least 10 percentage points between middle value and limit.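

No step can be read between compound 2 and compound 3, as both values are limits of the assay and not numbers: the limit of < 5% in this assay, at which 2 of the 3 values shown sit.

The compounds shown leave open whether azido and sulfanyl on the shared core differ at all in this assay, and whether either group would give a number on the sugar of compound 1.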